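Dropping the Chloro Group: From Compound 2 to Compound 4

The source may hold more compounds than are shown below. What is called first, only, known or untested is meant among the compounds shown, and "the series" means these compounds.

Compound 2 `C#Cc1nc(C(=O)Nc2ccc(Cl)cc2)cs1` holds the lowest of the two numbers in a functional assay on HCT-116 cells (Homo sapiens) for cytotoxicity, with a stated time of 3 days (a lower number here means a stronger inhibitor, a higher number a weaker inhibitor), where compound 2 gives 15900 nM. Its nearest neighbour is compound 1 `C#Cc1nc(/C=C/C(=O)Nc2ccc(Cl)cc2)cs1`, which in this assay gives 23200 nM, a gap that sits within the usual scatter, so no order between the two can be read. Compound 3 `N#Cc1nccs1` reaches only the limit of this assay, > 40000 nM; here (the limit of > 40000 nM in this assay, at which 1 of the 3 values shown sits).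

Compound 4 `C#Cc1nc(C(=O)Nc2ccccc2)cs1` differs from compound 2 by hydrogen in place of chloro on an aromatic carbon. Among the compounds with values here, no step between measured compounds is available to guide the expectation, so the change is judged on its own: only a small shift, if any, toward a weaker number is expected, a 1.6-fold higher number from compound 2 to compound 4 (0.20 log units; within the scatter), at or inside the scatter. Compound 4 is therefore estimated at 25000 nM, within a range from 10000 nM to 60000 nM.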

Compound 4, half-maximal inhibitory concentration: 4880 nM
Compound 4: the middle estimate sits 5.1-fold (0.71 log units) above what was measured, outside the stated range (below it).
By their numbers in this assay, from the lowest: compound 4; then compounds 2 and 1 (each within the scatter of the next). At a limit, above all of these: compound 3.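

In this assay, the aromatic carbon para to a large group turns out to matter: hydrogen in place of chloro gives a 3.3-fold lower number from compound 2 to compound 4 (0.51 log units; beyond the scatter). The chloro group is therefore not needed for the cytotoxicity seen here, and compound 4, which has no substituent at this place, gives the lower number. No measured property shown here bears on this step.

Going by these compounds, whether a fluoro, a methoxy or an amine at this carbon would give a number nearer to that of compound 4 or to that of compound 2 remains open. Also open, on these data alone, is whether the same change would have a similar effect on compound 1.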